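Two limits, then a swap on the shared core

The source may report more compounds than this note shows. Statements on the series, on what has been measured and on what is new or still open speak of the compounds shown alone.

In an ADME assay on PANC-1 cells (Homo sapiens) for cytotoxicity, read by MTT assay (a lower number here means that less compound is tolerated, a higher number that more compound is tolerated), the measured compounds are:
Compound 1 `Cc1nc(-c2cccnc2)sc1-c1nnc(Cc2ccccc2)o1` gives > 100 ug/mL as a limit
Compound 2 `Cc1nc(-c2cccnc2)sc1-c1nnc(-c2ccc(Cl)cc2)o1` gives > 100 ug/mL as a limit

Compound 2 therefore stands at a limit and not at a number, as does compound 1. Together they make up the limit of > 100 ug/mL in this assay, at which 2 of the 2 values shown sit, as the only evidence so far. Compound 3 `Cc1cccc(-c2nnc(-c3sc(-c4cccnc4)nc3C)o2)c1` changes one group on the shared core: 3-methylphenyl in place of 4-chlorophenyl on an aromatic carbon, with 3-methylphenyl in place of 4-chlorophenyl.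

Going by the values given here, the one measured step, a step that the two limits leave unreadable from compound 1 to compound 2, has no readable size, so for compound 3 no step beyond the scatter is expected in this assay in either direction, and another limit is likely. The expected change is a step that the limit leaves unreadable from compound 2 to compound 3 as estimated. For compound 3 the estimated value is 120 ug/mL, with an expected range of 60 ug/mL to 250 ug/mL around it.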

Compound 3, half-maximal cytotoxic concentration: > 100 ug/mL
Compound 3 ended at the assay's limit; the forecaster's own chance of this, stated with the estimate: 85%; the middle value is on the limit's open side.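

No step can be read among compound 1, compound 2 and compound 3 in this assay, because all three stop at the same limit: the limit of > 100 ug/mL in this assay, at which 3 of the 3 values shown sit. As far as these compounds go, the concentration at which each compound would become cytotoxic stays open.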